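Piperazine dimethylation in two related cyclopropyl cores

The source may hold more compounds than are shown below. What is called first, only, known or untested is meant among the compounds shown, and "the series" means these compounds.

Compound 1 `COc1c(N2CCNCC2)c(F)cc2c(=O)c(C(=O)O)cn(C3CC3)c12` and compound 2 `O=C(O)c1cn(C2CC2)c2nc(N3CCNCC3)c(F)cc2c1=O` share most of their structure; the difference between their two cores is not broken down here. In a functional assay on V79 cells (Cricetulus griseus) for cytotoxicity, read by colony formation (a lower number here means a stronger inhibitor, a higher number a weaker inhibitor), compound 1 gives 82 ug/mL and compound 2 gives 120 ug/mL, values that lie within the scatter of each other. Compound 3 `COc1c(N2CC(C)NC(C)C2)c(F)cc2c(=O)c(C(=O)O)cn(C3CC3)c12` gives > 500 ug/mL, a limit of the assay rather than a number. That value is the limit of > 500 ug/mL in this assay, at which 1 of the 3 values shown sits. The step of an at least 6.0-fold higher number from compound 1 to compound 3 (0.78 log units; beyond the scatter) comes from 3,5-dimethylpiperazin-1-yl in place of piperazin-1-yl on an aromatic carbon. Compound 4 `CC1CN(c2nc3c(cc2F)c(=O)c(C(=O)O)cn3C2CC2)CC(C)N1` carries the same kind of change against compound 2, (3,5-dimethylpiperazin-1-yl in place of piperazin-1-yl on an aromatic carbon), here on a six-membered aromatic ring with 1 nitrogen and next to the ring nitrogen, rather than on a ring of carbon only and ortho to a methoxy group. Since compound 2 starts from 120 ug/mL and the step of an at least 6.0-fold higher number from compound 1 to compound 3 (0.78 log units; beyond the scatter) is beyond the scatter, a step of a 6.7-fold higher number from compound 2 to compound 4 (0.82 log units; beyond the scatter) is expected. Compound 4 is accordingly estimated at 800 ug/mL, most probably reported again only as a limit.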

Compound 4, half-maximal inhibitory concentration: 250 ug/mL
For compound 4 the middle estimate is 3.2-fold (0.51 log units) above the measured one; measured number outside the range, below it.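

In this assay the change to 3,5-dimethylpiperazin-1-yl gives a 2.1-fold higher number from compound 2 to compound 4 (0.32 log units; beyond the scatter), the same direction as on the other core, but the size of the step does not carry over: the same change on two cores in this assay, an at least 6.0-fold higher number (0.78 log units; beyond the scatter) from compound 1 to compound 3 and a 2.1-fold higher number (0.32 log units; beyond the scatter) from compound 2 to compound 4, at least 2.9-fold (0.46 log units) apart, beyond the scatter of two such steps
The value of compound 3, > 500 ug/mL, is a limit of the assay and not a number. Two cores show only that the direction held in these two pairs, and they give no rule for the size of the step on a further core.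

As far as these compounds go, whether a single methyl on the piperazine ring or an open-chain amine in its place would move the number in the same direction stays open on both cores. Which part of the cores sets the gap between the two steps also stays open.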